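The source may hold more compounds than are shown below. What is called first, only, known or untested is meant among the compounds shown, and "the series" means these compounds.

Working notes on the series. Compound 3 `CC1(c2ccccc2)CC(=O)N(CC(=O)N2CCN(c3ccc(F)cc3)CC2)C1=O` stands lowest of the two numbers in a functional assay on the whole organism (strain CD-1) with Mus musculus as the target, in the maximal electroshock model, with a stated time of 0.5 h (a higher number here means that more compound is needed for the effect, a lower number that less compound is needed), where compound 3 gives 100 mg/kg. Compound 1 `CC1(c2ccccc2)CC(=O)N(CC(=O)N2CCN(c3cccc(Cl)c3)CC2)C1=O` gives 300 mg/kg in this assay, and compound 2 `COc1cccc(N2CCN(C(=O)CN3C(=O)CC(C)(c4ccccc4)C3=O)CC2)c1` is reported in this assay as "not active" (no number reported). Within the data shown here, the only measured step at the same ring nitrogen is a 3.0-fold lower number from compound 1 to compound 3 (0.48 log units; beyond the scatter). Compound 4 `CC1(c2ccccc2)CC(=O)N(CC(=O)N2CCN(c3cccc(C(F)(F)F)c3)CC2)C1=O` differs from compound 3 by 3-(trifluoromethyl)phenyl in place of 4-fluorophenyl on an amine nitrogen in a ring. The step from compound 1 to compound 3 shows that the group on this nitrogen moves the number by a modest amount, and compound 2 shows that it can remove activity altogether. Compound 4 is therefore expected to give a higher number than compound 3, an expected step of a 3.0-fold higher number from compound 3 to compound 4 (0.48 log units; beyond the scatter), with the estimate for compound 4 at 300 mg/kg, ranging from 100 mg/kg to 600 mg/kg.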

Compound 4, minimum effective dose: 300 mg/kg
Estimate against measurement, compound 4: no gap at the digits printed, within the range that was stated.
By their numbers in this assay, from the lowest: compound 3; then compounds 1 and 4 (each within the scatter of the next).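

In this assay, the change on the amine nitrogen gives a 3.0-fold higher number from compound 3 to compound 4 (0.48 log units; beyond the scatter), so 4-fluorophenyl stands apart from 3-(trifluoromethyl)phenyl at this position. Trifluoromethyl in place of chloro on the aromatic carbon gives no change at the digits printed from compound 1 to compound 4 (within the scatter), so these two groups are not told apart here, whereas compound 2 has no number.

Going by these compounds, the step to compound 4 changes the group and where it sits together, so the two effects cannot be separated, and a nitrile or an amine on this aromatic ring remains open. No data here explain these numbers.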